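This account rests on a few compounds, and the source may have more. Where it says the series, first, only, none or still open, it means among the compounds named here.

Compound 3 `COc1ccc(-c2cc3ccccc3nc2/C=C/C(=O)c2ccco2)cc1` gives the lowest of the three numbers measured in a functional assay on MCF7 cells (Homo sapiens) for antiproliferative activity, read by XTT assay, with a stated time of 72 h (on this read-out lower numbers stand for stronger inhibition and higher numbers for weaker inhibition), at 710 nM. Compound 1 `COc1ccc(C(=O)/C=C/c2nc3ccccc3cc2-c2ccc(OC)cc2)cc1` gives 7380 nM in this assay, and compound 2 `COc1ccc(-c2cc3ccccc3nc2/C=C/C(=O)c2c(OC)cccc2OC)cc1` gives 4520 nM. The step of a 10-fold lower number from compound 1 to compound 3 (1.02 log units; beyond the scatter) and the step of a 6.4-fold lower number from compound 2 to compound 3 (0.80 log units; beyond the scatter) both set compound 3 clearly apart from the other two, whereas the step of a 1.6-fold lower number from compound 1 to compound 2 (0.21 log units; within the scatter) does not separate those two from each other.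

Compound 4 `COc1ccc(-c2cc3ccccc3nc2/C=C/C(=O)c2ccccn2)cc1` is not yet measured. It differs from compound 3 in one place: pyridin-2-yl in place of furan-2-yl on a carbonyl carbon. The measured steps that bear on this change are those in which the group on the carbonyl carbon was exchanged, a 10-fold lower number from compound 1 to compound 3 (1.02 log units; beyond the scatter) and a 6.4-fold lower number from compound 2 to compound 3 (0.80 log units; beyond the scatter); both were large, but each replaced 4-methoxyphenyl or 2,6-dimethoxyphenyl with furan-2-yl, whereas here one heteroaromatic ring replaces another. Among the compounds with values here, no measured pair shows furan-2-yl exchanged for pyridin-2-yl at this place. The step from compound 3 to compound 4 in this assay is therefore expected to be of modest size, a 1.8-fold higher number from compound 3 to compound 4 (0.26 log units; within the scatter), with a higher number somewhat more likely than a lower one because compound 1 gives 7380 nM and compound 2 gives 4520 nM, both above compound 3. Compound 4 is expected to give about 1300 nM in this assay, within a range from 400 nM to 4500 nM.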

Compound 4, half-maximal inhibitory concentration: 810 nM
Compound 4: middle estimate off by 1.6-fold (0.21 log units), on the high side, and the stated range covers the measured number.
By their numbers in this assay, from the lowest: compounds 3 and 4 (each within the scatter of the next); then compounds 2 and 1 (each within the scatter of the next).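

In this assay, exchanging furan-2-yl for pyridin-2-yl on the carbonyl carbon, one five-membered aromatic ring for one six-membered aromatic ring, gives a 1.1-fold higher number from compound 3 to compound 4 (0.06 log units; within the scatter), so this change does not separate the two compounds and the low numbers at this place are not confined to furan-2-yl. Pyridin-2-yl also stands apart from the two methoxy-bearing groups, with a 5.6-fold lower number from compound 2 to compound 4 (0.75 log units; beyond the scatter) and a 9.1-fold lower number from compound 1 to compound 4 (0.96 log units; beyond the scatter), which means that among these four compounds the two with a single-hetero-atom aromatic ring on the carbonyl carbon both give lower numbers than the two with methoxy-bearing phenyl rings, and none goes against this. No available measurement bears on what lies behind these differences.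

The compounds shown leave open whether an unsubstituted phenyl ring on the carbonyl carbon would fall with compound 3 and compound 4 or with compound 1 and compound 2, which would indicate whether the ring hetero atom or the methoxy groups matter more. They also leave open whether other rings at this place, such as thiophen-2-yl or an imidazole, would give numbers like those of compound 3 and compound 4.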